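Adding a methyl: isopropyl becomes tert-butyl

The compounds below may be only part of what the source reports. "The series", "measured", "known", "first", "only" and "open" are said of these compounds alone.

Compound 1, `CC(C)N/C(=N\c1nccn1C(C)(C)C)Nc1ccc(Cl)c(Cl)c1`: 0.8 h
Compound 2, `CC(C)n1ccnc1/N=C(\N)Nc1ccc(Cl)c(Cl)c1`: > 1 h

In an in vitro ADME assay on microsomes from liver (Homo sapiens) for metabolic stability, read by LC-MS, tested at 1 uM (a lower number here means that the compound disappears faster, a higher number that the compound lasts longer), compound 1 gives 0.8 h. For compound 2 the reading is a limit of the assay, > 1 h, so only a range is known. One of the two values therefore sits at the limit of > 1 h in this assay, at which 1 of the 2 values shown sits.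

Compound 3, `CC(C)(C)n1ccnc1/N=C(\N)Nc1ccc(Cl)c(Cl)c1`, has not been measured. It differs from compound 2 by methyl in place of hydrogen on a saturated chain carbon bound to an aromatic nitrogen and two saturated chain carbons. Going by the values given here, no measured pair isolates this change, so the step in this assay is expected to be no larger than the usual scatter, in no clear direction: a step that the limit leaves unreadable from compound 2 to compound 3. Compound 3 is accordingly estimated at 1.2 h, between 0.6 h and 2.4 h.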

Compound 3, half-life: > 1 h
Compound 3 ended at the assay's limit; the forecaster's own chance of this, stated with the estimate: 50%; the middle value is on the limit's open side.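

In this assay compound 3 gives > 1 h, which is a limit of the assay. The change from isopropyl to tert-butyl therefore cannot be read, and the tert-butyl group can only be said to leave the reading at the same limit: the limit of > 1 h in this assay, at which 2 of the 3 values shown sit. Hydrogen in place of isopropyl on an amine nitrogen gives an at least 1.2-fold higher number from compound 1 to compound 3 (0.09 log units; that floor lies within the scatter).

Going by these compounds, how long compound 2 and compound 3 actually last remains open. So does whether a cyclopropyl group or a longer chain in place of the tert-butyl would give a reading inside the range of the assay.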